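The source may report more compounds than this note shows. Statements on the series, on what has been measured and on what is new or still open speak of the compounds shown alone.

In an ADME assay on microsomes from liver (Homo sapiens) for pharmacokinetics, read by LC-MS, with a stated time of 60 min, tested at 1 uM (on this read-out lower numbers stand for slow clearance and higher numbers for fast clearance), compound 1 `O=C(NCc1ccc(S(=O)(=O)c2cccc(C(F)(F)F)c2)cc1)N1Cc2ccncc2C1` gives 14 mL/min/kg while compound 2 `CC(=O)N1CCC(S(=O)(=O)c2ccc(CNC(=O)N3Cc4ccncc4C3)cc2)CC1` gives 6 mL/min/kg and compound 3 `O=C(NCc1ccc(S(=O)(=O)N2CCC[C@H](O)C2)cc1)N1Cc2ccncc2C1` gives 8 mL/min/kg as its read-out. Compound 3 therefore lies within the scatter of both other compounds, though those two stand apart (a 2.3-fold lower number from compound 1 to compound 2 (0.37 log units; beyond the scatter)). Compound 4 `CN1CCN(S(=O)(=O)c2ccc(CNC(=O)N3Cc4ccncc4C3)cc2)CC1` differs from compound 3 in one group: 4-methylpiperazin-1-yl in place of 3-hydroxypiperidin-1-yl on a sulfonyl sulfur. Two measured changes at that same place lead to compound 3 (a 1.8-fold lower number from compound 1 to compound 3 (0.24 log units; within the scatter) and a 1.3-fold higher number from compound 2 to compound 3 (0.12 log units; within the scatter)), and both stay within the scatter. In this assay the expected step is therefore none beyond the scatter (no change at the digits printed from compound 3 to compound 4 (within the scatter)). Compound 4 is estimated at 8 mL/min/kg (expected range 4 mL/min/kg to 16 mL/min/kg).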

Compound 4, clearance in the Homo sapiens assay: 9 mL/min/kg
Compound 4: the middle estimate sits 1.1-fold (0.05 log units) below what was measured; the measured number falls inside the stated range.
By their numbers in the Homo sapiens assay, from the lowest: compounds 2, 3, 4 and 1 (each within the scatter of the next, the first and the last beyond it).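

In the Homo sapiens assay, compound 4 gives 9 mL/min/kg, and the 4-methylpiperazin-1-yl group on the sulfonyl sulfur gives no step beyond the scatter against any earlier compound: a 1.1-fold higher number from compound 3 to compound 4 (0.05 log units; within the scatter), a 1.5-fold higher number from compound 2 to compound 4 (0.18 log units; within the scatter) and a 1.6-fold lower number from compound 1 to compound 4 (0.19 log units; within the scatter). Removing the hydrogen-bond donor and the defined stereocentre of 3-hydroxypiperidin-1-yl therefore has no clear effect on this read-out, and in a physicochemical assay for solubility, in phosphate buffer, with a stated time of 24 h, at pH 7.4, tested at 100 uM (a higher number here means a more soluble compound, a lower number a less soluble compound), the same change also stays within the scatter, with compound 3 at 215000 nM and compound 4 at 160000 nM (a 1.3-fold lower number from compound 3 to compound 4 (0.13 log units; within the scatter)). No supporting data explain these results. Going by these compounds, whether a morpholine ring or a carboxylic acid at this position would give a step beyond the scatter remains open.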